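The source may hold more compounds than are shown below. What is called first, only, known or untested is meant among the compounds shown, and "the series" means these compounds.

The study follows a short series built on a shared core. Compound 1 `CCCCC1CCC(OC(=O)N[C@@H](CC(C)C)C(=O)N[C@@H](C[C@@H]2CCNC2=O)C(O)S(=O)(=O)O)CC1` was examined in a toxicity assay on Huh-7 cells (Homo sapiens) for cytotoxicity (on this read-out lower numbers stand for higher toxicity in this test and higher numbers for lower toxicity in this test), where compound 1 gives 59100 nM. Compound 2 `CCCC1CCC(OC(=O)N[C@@H](CC(C)C)C(=O)N[C@@H](C[C@@H]2CCNC2=O)C(O)S(=O)(=O)O)CC1` differs from it by hydrogen in place of methyl on a saturated chain carbon, three bonds along the chain from a saturated ring carbon. In this assay compound 2 reaches only a limit of the test, > 100000 nM, and so stands without a number. That change amounts to an at least 1.6-fold higher number from compound 1 to compound 2 (0.22 log units; that floor lies within the scatter), and the limit of > 100000 nM in this assay, at which 1 of the 2 values shown sits, is what sets this floor. Compound 3 `CC(C)C[C@H](NC(=O)OC1CCC(F)(F)CC1)C(=O)N[C@@H](C[C@@H]1CCNC1=O)C(O)S(=O)(=O)O` has not yet been measured; it carries 4,4-difluorocyclohexyl in place of 4-propylcyclohexyl on an oxygen next to a carbonyl group. Among the compounds with values here, only the step from compound 1 to compound 2 bears on this change, and it was small and cut off by the limit. Compound 3 is therefore expected to show no step beyond the scatter, a number no higher from compound 2 to compound 3 (the limit leaves the size open), in this assay. The estimate for compound 3 is 100000 nM, within 40000 nM and 250000 nM.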

Compound 3, half-maximal cytotoxic concentration: > 100000 nM
Compound 3 was reported as a limit; the forecaster's own chance of this, stated with the estimate: 65%; the middle value lies on the limit itself.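

In this assay compound 3 gives > 100000 nM, which is a limit of the test and not a number. Within the data shown here, the one step that can be read is an at least 1.6-fold higher number from compound 1 to compound 3 (0.22 log units; that floor lies within the scatter), so 4,4-difluorocyclohexyl on an oxygen next to a carbonyl group, a group without any alkyl chain, also gives no number in this test, as 4-propylcyclohexyl did in compound 2. The step between compound 2 and compound 3 cannot be read, and the comparison at this position ends at the limit of the test: the limit of > 100000 nM in this assay, at which 2 of the 3 values shown sit.

The compounds shown leave open whether 4-propylcyclohexyl and 4,4-difluorocyclohexyl differ at all in this test. They also leave open whether a 4-hexylcyclohexyl or a 4-aminocyclohexyl group at this place would give a number rather than a limit.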